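Trading 3,4-dihydroxyphenyl for 4-fluorophenyl on the shared core

This account rests on a few compounds, and the source may have more. Where it says the series, first, only, none or still open, it means among the compounds named here.

In a functional assay on HepG2 cells (Homo sapiens) for inhibition, read by MTT assay, with a stated time of 48 h (on this read-out lower numbers stand for stronger inhibition and higher numbers for weaker inhibition), compound 1 (`COc1cc(C(=O)/C=C/c2ccc(N(C)C)cc2)cc(OC)c1OC`) gives 30000 nM and compound 2 (`COc1cc(C(=O)/C=C/c2ccc(O)c(O)c2)cc(OC)c1OC`) gives 14900 nM, so compound 2 stands level with compound 1 within the usual scatter. Compound 3 (`COc1cc(C(=O)/C=C/c2ccc(F)cc2)cc(OC)c1OC`) carries 4-fluorophenyl in place of 3,4-dihydroxyphenyl on a double-bonded chain carbon bound to a double-bonded chain carbon. No measured single-place change is available as a guide. The expected step in this assay, a 1.2-fold higher number from compound 2 to compound 3 (0.08 log units; within the scatter), is therefore none beyond the scatter. Compound 3 is estimated at 18000 nM, with an expected range of 6000 nM to 50000 nM.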

Compound 3, half-maximal inhibitory concentration: 22000 nM
The estimate for compound 3 lay 1.2-fold (0.09 log units) below the measured number, and the stated range covers the measured number.
By their numbers in this assay, from the lowest: compounds 2, 3 and 1 (each within the scatter of the next).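

In this assay, 4-fluorophenyl in place of 3,4-dihydroxyphenyl gives a 1.5-fold higher number from compound 2 to compound 3 (0.17 log units; within the scatter), and fluoro in place of dimethylamino on an aromatic carbon gives a 1.4-fold lower number from compound 1 to compound 3 (0.13 log units; within the scatter). On a double-bonded chain carbon, 4-fluorophenyl carries 0 hydrogen-bond donors where 3,4-dihydroxyphenyl carries 2, yet the two stand level, and all three compounds shown lie within the scatter of one another. No measurement at hand bears on why these groups stand level.

On these data alone, whether a carboxylic acid or a longer chain in this place would move the number beyond the scatter stays open. So does whether any change elsewhere on the shared core would.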